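Pyrimidine substituent swap in a cAMP agonist series

This account rests on a few compounds, and the source may have more. Where it says the series, first, only, none or still open, it means among the compounds named here.

Measured compounds:
compound 1 `CCCS(=O)(=O)N1CC=C(c2ccc3c(c2)CC(C2CCN(S(=O)(=O)CCC)CC2)O3)CC1` with 1000 nM
compound 2 `CCCS(=O)(=O)N1CC=C(c2ccc3c(c2)CC(C2CCN(c4ncc(C(F)(F)F)cn4)CC2)O3)CC1` with 14 nM

Both were tested in a functional assay on HEK293 cells for agonist activity at Glucose-dependent insulinotropic receptor (Homo sapiens), read by cAMP accumulation, with a stated time of 60 min; on this read-out lower numbers stand for an effect already at smaller amounts and higher numbers for an effect only at larger amounts of compound. Within the data shown here, compound 2 holds the lowest of the two numbers; its only neighbour is compound 1, and the step of a 71-fold lower number from compound 1 to compound 2 (1.85 log units; beyond the scatter) is large and beyond the scatter.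

Compound 3 `CCCS(=O)(=O)N1CC=C(c2ccc3c(c2)CC(C2CCN(c4ncc(C5CC5)cn4)CC2)O3)CC1` is not yet measured. It differs from compound 2 by cyclopropyl in place of trifluoromethyl on an aromatic carbon. Among the measured compounds shown here, no measured step concerns this pyrimidine substituent; the single measured step covers the group on the amine nitrogen and says nothing about the trifluoromethyl. The change is small in heavy-atom count and neutral in donors, acceptors and charge, so for compound 3 a step within or close to the scatter is expected, a 1.8-fold higher number from compound 2 to compound 3 (0.25 log units; within the scatter). The estimate for compound 3 is 25 nM, with a range from 8 nM to 80 nM.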

Compound 3, half-maximal effective concentration: 67 nM
Estimate against measurement, compound 3: 2.7-fold (0.43 log units) below, within the range that was stated.
By their numbers in this assay, from the lowest: compound 2; then compound 3; then compound 1.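

In this assay, the group on this aromatic carbon, para to a large group, does matter: a 4.8-fold higher number from compound 2 to compound 3 (0.68 log units; beyond the scatter) is a modest step beyond the scatter, with trifluoromethyl giving the lower number. The large improvement over the propylsulfonyl compound does not require trifluoromethyl, as a 15-fold lower number from compound 1 to compound 3 (1.17 log units; beyond the scatter) remains large and beyond the scatter with 5-cyclopropylpyrimidin-2-yl on the amine nitrogen. Nothing available accounts for the difference between trifluoromethyl and cyclopropyl at this position.

Still open, going by these compounds, is how a nitrile, a methoxy group or a plain hydrogen on this aromatic carbon would compare with these two groups. Also open, on these data alone, is whether trifluoromethyl and cyclopropyl keep the same order when the remaining propylsulfonyl group is replaced by an acetyl group.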